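Oxime ether series, cytotoxicity on A549 cells

This account rests on a few compounds, and the source may have more. Where it says the series, first, only, none or still open, it means among the compounds named here.

Measured compounds:
compound 1 `Cc1nn(C)c(-n2cccc2)c1/C=N/OCc1ccc(C(=O)OC(C)(C)C)cc1`, 1.64 ug/mL
compound 2 `Cc1nn(C)c(-n2ccc3ccccc32)c1/C=N/OCc1ccc(C(=O)OC(C)(C)C)cc1`, 0.43 ug/mL

For the measured compounds named here, in a functional assay on A549 cells (Homo sapiens) for cytotoxicity (a higher number here means a weaker inhibitor, a lower number a stronger inhibitor), compound 2 stands at the lowest of the two numbers; its only neighbour is compound 1, and the step of a 3.8-fold lower number from compound 1 to compound 2 (0.58 log units; beyond the scatter) is the one comparison available. Compound 3 `Cc1nn(C)c(Oc2ccc(Cl)cc2)c1/C=N/OCc1ccc(C(=O)OC(C)(C)C)cc1` has not been measured. Its change from compound 2 is 4-chlorophenoxy in place of 1H-indol-1-yl on an aromatic carbon. Going by the values given here, no measured step covers an oxygen-linked aryl group at this ring carbon; the one measured step concerns the exchange of two nitrogen-linked rings at the same carbon and was modest in size. Since replacing the smaller nitrogen-linked ring by the larger one lowered the number, and the entering group is closer in size to the leaving indolyl than to the pyrrolyl of compound 1, a small rise back toward the value of compound 1 is expected, with a 2.3-fold higher number from compound 2 to compound 3 (0.37 log units; beyond the scatter) not certainly beyond the scatter. The estimate for compound 3 in this assay is 1 ug/mL, expected within 0.4 ug/mL to 2.5 ug/mL.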

Compound 3, half-maximal inhibitory concentration: 0.1 ug/mL
For compound 3 the middle estimate is 10-fold (1.00 log units) above the measured one; measured number below the stated range.
By their numbers in this assay, from the lowest: compound 3; then compound 2; then compound 1.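

In this assay, the nitrogen-linked rings are not the best of the groups seen at this aromatic carbon: 4-chlorophenoxy gives the lowest number of the three compounds, both against 1H-indol-1-yl (a 4.3-fold lower number from compound 2 to compound 3 (0.63 log units; beyond the scatter)) and against 1H-pyrrol-1-yl (a 16-fold lower number from compound 1 to compound 3 (1.21 log units; beyond the scatter)). 4-Chlorophenoxy has fewer heavy atoms than 1H-indol-1-yl, so the number does not follow heavy-atom count across these compounds. Nothing available accounts for this difference.

From the compounds shown here alone, the change brings in the oxygen link and the chlorine together, so the share of each stays open; phenoxy without chlorine, or an anilino group carrying the same chlorine, would separate them. Also open, going by these compounds, is whether this order holds with a carboxylic acid in place of the tert-butyl ester.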